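The compounds below may be only part of what the source reports. "The series", "measured", "known", "first", "only" and "open" are said of these compounds alone.

In a functional assay for inhibition, with Homo sapiens as the target (on this read-out higher numbers stand for weaker inhibition and lower numbers for stronger inhibition), compound 1 `CCCc1nc(C)c2c(C(C)C)nnc(S)n12` gives only a limit of the assay, > 48000 nM. Compound 2 `CCCc1nc(C)c2c(CC)nnc(S)n12` likewise stops at a limit in this assay, > 48000 nM. The change between them, (hydrogen in place of methyl on a saturated chain carbon bound to an aromatic carbon and a saturated chain carbon), therefore produced a step that the two limits leave unreadable from compound 1 to compound 2. Compound 3 `CCCc1nc(C)c2c(CC)cnc(Nc3cc[nH]n3)n12` also returns only a limit in this assay, > 48000 nM; the difference between its core and the core of compound 1 is not broken down here. All three values sit at the same point, (the limit of > 48000 nM in this assay, at which 3 of the 3 values shown sit). Compound 4 `CCCc1nc(C)c2c(C)cnc(Nc3cc[nH]n3)n12` differs from compound 3 by hydrogen in place of methyl on a saturated chain carbon bound to an aromatic carbon, the same kind of change as from compound 1 to compound 2, though there the place was bound to an aromatic carbon and a saturated chain carbon, here to an aromatic carbon only. Because compound 3 gives > 48000 nM, compound 4 is expected to show a step that the limit leaves unreadable from compound 3 to compound 4 in this assay, and its estimated value is 100000 nM, most likely again only a limit, within 20000 nM to 500000 nM.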

Compound 4, half-maximal inhibitory concentration: > 48000 nM
Compound 4 was reported as a limit (the forecaster's own chance of this, stated with the estimate: 90%); the middle value lies beyond the limit too.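

Compound 3 and compound 4 both return only a limit in this assay, so no step can be read between them. The compounds shown leave open what value any of them would reach past that shared limit: the limit of > 48000 nM in this assay, at which 4 of the 4 values shown sit.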